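Compound 3 swaps the furan-2-yl group of compound 2

The source may hold more compounds than are shown below. What is called first, only, known or untested is meant among the compounds shown, and "the series" means these compounds.

Measured in a functional assay on SMMC-7721 cells (Homo sapiens) for antiproliferative activity, read by MTT assay, with a stated time of 72 h; a higher number here means a weaker inhibitor, a lower number a stronger inhibitor
Compound 1 `C/C(=N\NC(=O)c1cccc(S(=O)(=O)N2CCOCC2)c1)c1cccc(N)c1` gives > 100000 nM (a limit)
Compound 2 `O=C(N/N=C/c1ccco1)c1cccc(S(=O)(=O)N2CCOCC2)c1` gives > 100000 nM (a limit)

Neither measured compound has a number to offer. Compound 2 gives only > 100000 nM in this assay, and this is a limit of the assay. Among the measured compounds shown here, it shares that position with compound 1, as the pair together shows (the limit of > 100000 nM in this assay, at which 2 of the 2 values shown sit), so no measured step exists to scale from.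

Compound 3 `O=C(N/N=C/c1cc(Cl)ccc1O)c1cccc(S(=O)(=O)N2CCOCC2)c1` keeps the shared core and carries 5-chloro-2-hydroxyphenyl in place of furan-2-yl on a carbon with a double bond to nitrogen.

Compound 2 stands at a limit (> 100000 nM), so any measurable value for the new compound could lie only on the stronger side. A step beyond the scatter towards stronger inhibition is expected, though another limit remains quite possible. The estimated change is an at least 6.6-fold lower number from compound 2 to compound 3 (0.82 log units; beyond the scatter) in this assay. Compound 3 is estimated at 15000 nM, with an expected range of 1500 nM to 100000 nM.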

Compound 3, half-maximal inhibitory concentration: 6820 nM
Estimate against measurement, compound 3: 2.2-fold (0.34 log units) above; measured number inside the range.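

In this assay, the group on the carbon with a double bond to nitrogen proves able to move the result out of the limit: putting 5-chloro-2-hydroxyphenyl in place of furan-2-yl gives an at least 14-fold lower number from compound 2 to compound 3 (1.16 log units; beyond the scatter). Compound 3 is the only one of the compounds shown that has a number rather than a limit, so this position now has a measured point from which other changes can be scaled. The true size of the step remains unknown because compound 2 stands at a limit of the assay: the limit of > 100000 nM in this assay, at which 2 of the 3 values shown sit.

This one change swaps the ring and brings in the hydroxy group and the chlorine together, so the compounds shown do not separate what each part contributes. As far as these compounds go, whether an unsubstituted phenyl, or an amine in place of the hydroxy group, would also give a measurable value remains open.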